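Changing One Aromatic Group in a Level Series

This account rests on a few compounds, and the source may have more. Where it says the series, first, only, none or still open, it means among the compounds named here.

Measured in a functional assay on MCF7 cells (Homo sapiens) for inhibition, read by sulforhodamine B assay, with a stated time of 48 h, tested at 50 uM; a higher number here means more inhibition of growth at the concentration tested, a lower number less inhibition of growth:
- compound 1 `COc1ccc([C@@H]2C/C(=N/OCc3cn(-c4ccc(C#N)cc4)nn3)c3cc(CC=C(C)C)c(OC)cc3O2)cc1` gives 40%
- compound 2 `COc1ccc([C@@H]2C/C(=N/OCc3cn(-c4ccc(Cl)cc4C)nn3)c3cc(CC=C(C)C)c(OC)cc3O2)cc1` gives 37%
- compound 3 `COc1ccc([C@@H]2C/C(=N/OCc3cn(-c4cccc(CO)c4)nn3)c3cc(CC=C(C)C)c(OC)cc3O2)cc1` gives 42%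

These compounds share one core and differ only in the aromatic group on a ring nitrogen. Compound 3 gives 42% and stands level with the other two: a number 2 percentage points higher from compound 1 to compound 3 (within the scatter) and a number 5 percentage points higher from compound 2 to compound 3 (within the scatter). No order can be read among the three.

The next compound is compound 4 `COc1ccc([C@@H]2C/C(=N/OCc3cn(-c4cc(OC)c(OC)c(OC)c4)nn3)c3cc(CC=C(C)C)c(OC)cc3O2)cc1`. It keeps the core and has 3,4,5-trimethoxyphenyl in place of 3-(hydroxymethyl)phenyl on an aromatic nitrogen.

For the measured compounds named here, all the measured steps bear on this, since each is an exchange at that same place. Beside the two already given there is a number 3 percentage points lower from compound 1 to compound 2 (within the scatter). All three are small, even though the groups exchanged are quite different. However, no measured compound carries the 3,4,5-trimethoxyphenyl group, so the range must stay wide. On this evidence, no step beyond the scatter is expected in this assay. The estimated step is a number 1 percentage points lower from compound 3 to compound 4 (within the scatter). Compound 4 is therefore estimated at 41%, with an expected range from 30% to 54%.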

Compound 4, percent growth inhibition at one concentration: 45%
For compound 4 the middle estimate is 4 percentage points below the measured one; measured number inside the range.
By their numbers in this assay, from the lowest: compounds 2, 1, 3 and 4 (each within the scatter of the next).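

The group that enters, 3,4,5-trimethoxyphenyl, has more heavy atoms than 3-(hydroxymethyl)phenyl, no hydrogen-bond donor and more hydrogen-bond acceptors, yet in this assay the exchange gives a number 3 percentage points higher from compound 3 to compound 4 (within the scatter) and leaves the series level. The comparisons with the other two compounds agree, giving a number 8 percentage points higher from compound 2 to compound 4 (within the scatter) and a number 5 percentage points higher from compound 1 to compound 4 (within the scatter) as the remaining steps, so all four aromatic groups on this ring nitrogen read alike, even with this larger group in place. Nothing available explains why such different groups give such similar readings.

All four groups shown are substituted phenyl rings, so it remains open whether an aminomethyl group or a carboxylic acid on the phenyl ring, or a longer alkyl chain in place of that ring, would move the reading beyond the scatter. On these data alone, it also remains open whether these four compounds would still read alike at other concentrations, or whether a full concentration series would separate them.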